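The compounds below may be only part of what the source reports. "The series", "measured", "known", "first", "only" and "open" are said of these compounds alone.

Measured so far:
compound 1 `COc1cc(/C=C2\CCC/C(=C\c3ccccc3[N+](=O)[O-])C2=O)cc(Br)c1OC`: 3.35 ug/mL
compound 2 `COc1cc(/C=C2\CCC/C(=C\c3cccc([N+](=O)[O-])c3)C2=O)cc(Br)c1OC`: 4.72 ug/mL

In a functional assay on MCF7 cells (Homo sapiens) for cytotoxicity, read by MTT assay (a higher number here means a weaker inhibitor, a lower number a stronger inhibitor), compound 1 gives 3.35 ug/mL and compound 2 gives 4.72 ug/mL. For the measured compounds named here, the single step in hand, a 1.4-fold higher number from compound 1 to compound 2 (0.15 log units; within the scatter), stays within the scatter, so compound 2 cannot be set apart from compound 1 on these numbers.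

Compound 3 `CCOc1c(Br)cc(/C=C2\CCC/C(=C\c3cccc([N+](=O)[O-])c3)C2=O)cc1OC` differs from compound 2 by methyl in place of hydrogen on a saturated chain carbon bound to an oxygen on an aromatic ring, methoxy to ethoxy. Going by the values given here, no measured step touches this position: the one step recorded concerns the nitrophenyl and does not bear on it. With nothing pointing either way, no step beyond the scatter is expected, a 1.0-fold lower number from compound 2 to compound 3 (0.00 log units; within the scatter). Compound 3 is therefore estimated at 4.7 ug/mL, with a range of 2.3 ug/mL to 9.5 ug/mL.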

Compound 3, half-maximal inhibitory concentration: 24.9 ug/mL
Compound 3: the middle estimate sits 5.3-fold (0.72 log units) below what was measured, and the stated range ends below it.
By their numbers in this assay, from the lowest: compounds 1 and 2 (each within the scatter of the next); then compound 3.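

In this assay, for the compounds shown here, methoxy to ethoxy gives a 5.3-fold higher number from compound 2 to compound 3 (0.72 log units; beyond the scatter) and so moves the number beyond the scatter, whereas the only earlier step, on the nitrophenyl, stayed within it. This saturated chain carbon bound to an oxygen on an aromatic ring is therefore sensitive to one added methyl, at least with the 3-nitrophenyl group present. No measurement in hand accounts for this step.

Open, as far as these compounds go, is whether a longer chain such as propoxy, or a hydroxy group in place of methoxy, would raise the number further. Also open, from the compounds shown here alone, is whether ethoxy gives a similar step with the 2-nitrophenyl group of compound 1.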